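The compounds below may be only part of what the source reports. "The series", "measured", "known", "first", "only" and "open" are said of these compounds alone.

Among the compounds with values here, compound 1 `Cc1ccc(OCC(=O)NNC(=O)c2cc3ccccc3oc2=O)c(C(=O)c2ccccc2Cl)c1` gives 45200 nM in a functional assay on Ehrlich cells (Mus musculus) for cytotoxicity, read by MTT assay, with a stated time of 48 h; on this read-out higher numbers stand for weaker inhibition and lower numbers for stronger inhibition; this is the higher of the two numbers so far, with the gap to compound 2 lying within the scatter. Compound 2 `Cc1ccc(OCC(=O)NNC(=O)c2cc3ccccc3oc2=O)c(C(=O)c2ccc(F)cc2)c1` gives 39700 nM in this assay. Within the data shown here, the one measured step, a 1.1-fold lower number from compound 1 to compound 2 (0.06 log units; within the scatter), also exchanges the aryl group on the carbonyl carbon and stays within the scatter. Compound 3 `Cc1ccc(C(=O)c2cc(C)ccc2OCC(=O)NNC(=O)c2cc3ccccc3oc2=O)cc1` differs from compound 1 by 4-methylphenyl in place of 2-chlorophenyl on a carbonyl carbon. On that basis no step beyond the scatter is expected in this assay. The estimate for compound 3 is 42000 nM, with a range from 20000 nM to 90000 nM. This amounts to an expected step of a 1.1-fold lower number from compound 1 to compound 3 (0.03 log units; within the scatter).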

Compound 3, half-maximal inhibitory concentration: 78100 nM
Compound 3: the middle estimate sits 1.9-fold (0.27 log units) below what was measured; the range from low to high includes it.
By their numbers in this assay, from the lowest: compounds 2, 1 and 3 (each within the scatter of the next).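

The step to 4-methylphenyl on the carbonyl carbon gives a 1.7-fold higher number from compound 1 to compound 3 (0.24 log units; within the scatter) and methyl in place of fluoro on an aromatic carbon gives a 2.0-fold higher number from compound 2 to compound 3 (0.29 log units; within the scatter) in this assay and both lie within the scatter. This position has now carried chloro, fluoro and methyl aryl groups with no step beyond the scatter among compounds 1, 2 and 3. From the compounds shown here alone, whether an amine or a carboxylic acid on that aryl ring would give a step beyond the scatter stays open, as does the effect of a longer chain in its place. No supporting evidence bears on this result.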